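Sulfonyl aryl exchange in a chromone-type series: BJ antiproliferation

A few compounds are considered here, and "the series" means these few. Any claim that something is new, unique, unknown or untested is made for them only; others in the source may bear on it.

Measured so far:
compound 1 `COC(=O)c1cc(=O)c2c(OC)cc(OC)cc2n1S(=O)(=O)c1ccc(C)cc1` — 139000 nM
compound 2 `COc1ccc(-c2cc(=O)c3c(OC)cc(OC)cc3n2S(=O)(=O)c2ccc(C)c([N+](=O)[O-])c2)cc1` — > 51700 nM

Both compounds share the same core and were run in an ADME assay on BJ cells (Homo sapiens) for antiproliferative activity, with a stated time of 72 h; a higher number here means that more compound is needed for the effect, a lower number that less compound is needed. Compound 1 `COC(=O)c1cc(=O)c2c(OC)cc(OC)cc2n1S(=O)(=O)c1ccc(C)cc1` gives 139000 nM in this assay, a weak effect. For compound 2 `COc1ccc(-c2cc(=O)c3c(OC)cc(OC)cc3n2S(=O)(=O)c2ccc(C)c([N+](=O)[O-])c2)cc1` only a limit is recorded in this assay, > 51700 nM, as noted in the limit of > 51700 nM in this assay, at which 1 of the 2 values shown sits. Among the compounds with values here, no step between two measured compounds is available, so compound 2 stands at the limit and nothing can be said about its order relative to compound 1.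

The unmeasured compound 3 `COc1ccc(-c2cc(=O)c3c(OC)cc(OC)cc3n2S(=O)(=O)c2ccc(Br)s2)cc1` differs from compound 2 in one place:
5-bromothiophen-2-yl in place of 4-methyl-3-nitrophenyl on a sulfonyl sulfur

With compound 2 at the limit and compound 1 also weak, the expected step from compound 2 to compound 3 in this assay is a step that the limit leaves unreadable from compound 2 to compound 3, that is, no change beyond the scatter is expected. For compound 3 the expected value in this assay is 70000 nM, with a range from 20000 nM to 300000 nM, and a real chance that only a limit is again reported.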

Compound 3, half-maximal effective concentration: > 48200 nM
Compound 3: no number, only a limit; the forecaster's own chance of this, stated with the estimate: 60%; the middle value does not contradict the limit.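

Within the data shown here, compound 2 and compound 3 each carry only a limit in this assay, and no step between them can be read. The compounds shown leave open where the half-maximal effective concentrations of compound 2 and compound 3 lie, and how 5-bromothiophen-2-yl and 4-methyl-3-nitrophenyl on a sulfonyl sulfur compare.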